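Chloro for ethyl on the benzoate ester of compound 2

The compounds below may be only part of what the source reports. "The series", "measured", "known", "first", "only" and "open" are said of these compounds alone.

compound 1 `Fc1ccc(-c2cn(-c3ccnc4cc(Cl)ccc34)nn2)cc1` — an ADME assay on HepG2 cells (Homo sapiens) for cytotoxicity, read by MTT assay, with a stated time of 24 h; a lower number here means that less compound is tolerated, a higher number that more compound is tolerated: > 3080000 nM
compound 2 `CCc1ccc(C(=O)OCc2cn(-c3ccnc4cc(Cl)ccc34)nn2)cc1` — this assay : > 2550000 nM

Compound 2 stands at a limit of this assay, so its value is not a number (the limit of > 2550000 nM in this assay, at which 1 of the 2 values shown sits). Compound 1 also sits at a limit (the limit of > 3080000 nM in this assay, at which 1 of the 2 values shown sits). Compound 3 `O=C(OCc1cn(-c2ccnc3cc(Cl)ccc23)nn1)c1ccc(Cl)cc1` differs from compound 2 by chloro in place of ethyl on an aromatic carbon. Within the data shown here, no measured step between compounds differing in one place is available. The step from compound 2 to compound 3 is expected to be none beyond the scatter, a step that the limit leaves unreadable from compound 2 to compound 3. Compound 3 is therefore estimated at 2600000 nM, ranging from 1000000 nM to 6000000 nM, and is expected most likely to be reported as a limit again.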

Compound 3, half-maximal cytotoxic concentration: 484000 nM
The estimate for compound 3 lay 5.4-fold (0.73 log units) above the measured number; the measured number lies below the stated range.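

Going from 4-ethylphenyl to 4-chlorophenyl gives an at least 5.2-fold lower number from compound 2 to compound 3 (0.72 log units; beyond the scatter) in this assay. Among these compounds, this shows that the group on the aromatic carbon of this benzoate ring can move the reading beyond the scatter, which neither earlier compound could show, and compound 3 is the first with a number rather than a limit. Compound 2 sits at a limit, so the full size of the step stays unknown: the limit of > 2550000 nM in this assay, at which 1 of the 3 values shown sits.

Going by these compounds, whether the lower number follows from chloro itself or from the loss of ethyl stays open. So does what an amine, a carboxylic acid or a longer chain would give at this place.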